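Swapping bromo for methyl on a trifluoromethanesulfonamide series

A few compounds are considered here, and "the series" means these few. Any claim that something is new, unique, unknown or untested is made for them only; others in the source may bear on it.

Measured so far:
- compound 1 `O=S(=O)(Nc1ccncc1Nc1cccc(Br)c1)C(F)(F)F` gives 28.5% in a functional assay on the whole organism (strain Wistar) with Rattus norvegicus as the target, with stated times of 30 min and 4 h, at a dose of 20 mg/kg by the intraperitoneal route; a higher number here means a stronger effect of the compound at the dose given, a lower number a weaker effect
- compound 2 `Cc1ccc(Nc2cnccc2NS(=O)(=O)C(F)(F)F)cc1Br` gives 44.1% in this assay

Compound 1 stands lowest of the two numbers; its nearest neighbour is compound 2, and the step of a number 15.6 percentage points higher from compound 1 to compound 2 (beyond the scatter) lies beyond the scatter. Compound 3 `Cc1cccc(Nc2cnccc2NS(=O)(=O)C(F)(F)F)c1` has not been measured. It differs from compound 1 in this way: methyl in place of bromo on an aromatic carbon. Going by the values given here, no measured step shows a bromo being replaced by a methyl, so nothing here bears directly on this change. Among the compounds with values here, the only step on record, from compound 1 to compound 2, concerns a methyl added while the bromo is kept, and it was modest. Without a step of the same kind, the expected step of a number 1.5 percentage points higher from compound 1 to compound 3 (within the scatter) is none beyond the scatter. Compound 3 is therefore estimated at 30%, with a range from 10% to 55%.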

Compound 3, a percentage reported as activity, at one dose (the size of the read-out at that dose, not a potency): 50.2%
The estimate for compound 3 lay 20.2 percentage points below the measured number; low and high end bracket the measured number.
By their numbers in this assay, from the lowest: compound 1; then compounds 2 and 3 (each within the scatter of the next).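

In this assay, methyl in place of bromo on this aromatic carbon gives a number 21.7 percentage points higher from compound 1 to compound 3 (beyond the scatter), so bromo is not required here for the effect at this dose, and a single carbon in its place gives a larger read-out. Going by these compounds alone, this is the first direct reading of a change at this carbon itself, whereas the earlier step added a methyl elsewhere on the ring and kept the bromo. No measurement here explains why the swap raises the read-out.

The compounds shown leave open whether the gain is particular to methyl, a question that a chloro, a methoxy or an amine on this carbon would help to answer. From the compounds shown here alone, each number also describes one dose only, so how potency changes from the 3-bromophenyl to the 3-methylphenyl compound remains unknown.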